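This account rests on a few compounds, and the source may have more. Where it says the series, first, only, none or still open, it means among the compounds named here.

In a functional assay on the whole organism for inhibition, with Rattus norvegicus as the target (on this read-out higher numbers stand for an effect only at larger amounts of compound and lower numbers for an effect already at smaller amounts), three compounds have been measured so far. Compound 1 (`CS(=O)(=O)c1ccc2c(c1)c(C1CCN(CCN3CCNC3=O)CC1)cn2-c1ccc(F)cc1`) gives 54 umol/kg, compound 2 (`Fc1ccc(-n2cc(C3=CCNCC3)c3cc(Cl)ccc32)cc1`) gives 1.5 umol/kg, and compound 3 (`CN1CC=C(c2cn(-c3ccc(F)cc3)c3ccc(Cl)cc23)CC1`) gives 0.058 umol/kg. Compound 2 therefore holds the second highest of the three numbers, with compound 1 above it and compound 3 below it.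

Compound 4 (`Fc1ccc(-n2cc(C3=CCNCC3)c3cc(C(F)(F)F)ccc32)cc1`) has not been measured yet. It differs from compound 2 in one place, with trifluoromethyl in place of chloro on an aromatic carbon.

Within the data shown here, only one measured step links compound 2 to a compound that differs in a single place: a 26-fold lower number from compound 2 to compound 3 (1.41 log units; beyond the scatter). This large step came with methyl in place of hydrogen on an amine nitrogen in a ring. Among the measured compounds shown here, it shows that the numbers in this assay can move far after a single replacement, but it lies at a different place from the one that changes in compound 4. For the measured compounds named here, no measured pair tests a replacement of the chloro group, so the data offer no direct guide. The working expectation is therefore no step beyond the scatter, held with a wide margin. The expected step is a 1.3-fold higher number from compound 2 to compound 4 (0.12 log units; within the scatter). For compound 4 the estimated value is 2 umol/kg, with an expected range from 0.5 umol/kg to 8 umol/kg.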

Compound 4, dose for half-maximal effect: > 0.86 umol/kg
Compound 4 was reported as a limit (the forecaster's own chance of this, stated with the estimate: 5%); the middle value lies beyond the limit too.
By their numbers in this assay, from the lowest: compound 3; then compound 2; then compound 1.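

In this assay compound 4 gives > 0.86 umol/kg, which is a limit of the assay and not a number. The step from compound 2 to compound 4 cannot be read from it. The compounds shown leave open whether trifluoromethyl in place of chloro on an aromatic carbon changes the number beyond the scatter, and in which direction.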